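This account rests on a few compounds, and the source may have more. Where it says the series, first, only, none or still open, it means among the compounds named here.

Two amides with long unsaturated chains have been tested for how strongly they block platelet clumping. Compound 1 `C/C=C/C=C/C=C\CC/C=C/C=C/C(=O)NC(C)(C)O` and compound 2 `CCCCCCCCC/C=C/C=C/C(=O)NCC(C)(C)O` share an amide linked to a short hydroxylated group, but their chains differ in length of the unsaturated stretch and in the tail. In a functional assay on cells (Platelet, Oryctolagus cuniculus) for inhibition, read by turbidimetry, with a stated time of 3 min, tested at 100 ug/mL (a lower number here means a stronger effect, a higher number a weaker effect of the compound at the concentration tested), compound 1 gives 78.6%, while compound 2 gives 6.7%, the lowest number of the two and therefore the stronger blocker, the gap lying beyond the scatter.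

Compound 3 `CC/C=C/C/C=C\CC/C=C/C=C/C(=O)NCC(C)(C)O` keeps the amide part of compound 2 and changes only the tail: hepta-1,4-dien-1-yl in place of heptyl on a saturated chain carbon, two bonds along the chain from a double-bonded chain carbon. Among the compounds with values here, no step between measured compounds shows what such a change does by itself. Compound 1, whose chain carries additional double bonds, gives the far higher value 78.6%, so compound 3 is expected to move in the direction of a weaker effect, with a step of a number 28.3 percentage points higher from compound 2 to compound 3 (beyond the scatter) from compound 2, though its size is uncertain because compound 1 also differs at the amide end. For compound 3 the estimate in this assay is 35%, within a range from 8% to 70%.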

Compound 3, a percentage reported as activity, at one concentration (the size of the read-out at that concentration, not a potency): 38.4%
Estimate against measurement, compound 3: 3.4 percentage points below; low and high end bracket the measured number.
By their numbers in this assay, from the lowest: compound 2; then compound 3; then compound 1.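

In this assay, putting hepta-1,4-dien-1-yl in place of heptyl on a saturated chain carbon, two bonds along the chain from a double-bonded chain carbon, weakens the effect, with a number 31.7 percentage points higher from compound 2 to compound 3 (beyond the scatter). Within the data shown here, this is the first clean view of the tail: the amide end stays the same, and both groups have 7 carbon atoms and no ring, so the 2 double bonds of the entering group are the counted difference, and in this pair the saturated heptyl goes with the stronger effect. Nothing on hand explains why the tail's double bonds go with this weaker effect.

This single pair cannot show whether both double bonds matter or just one of them, a question that a tail with one double bond, such as hept-1-en-1-yl, could help settle. It also leaves open whether a longer saturated chain such as nonyl would keep the effect of heptyl, and whether the same step would appear if a carboxylic acid replaced the hydroxylated amide end.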